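The source may report more compounds than this note shows. Statements on the series, on what has been measured and on what is new or still open speak of the compounds shown alone.

The compounds share one core and differ only in the group attached to it. Compound 1 `CCC1=C(O)c2c(oc(-c3ccc(F)cc3)cc2=O)C(CC)(CC)C1=O` carries a 4-fluorophenyl group, and in a functional assay on KB cells (Homo sapiens) for antiproliferative activity, read by sulforhodamine B assay, with a stated time of 3 days (on this read-out lower numbers stand for an effect already at smaller amounts and higher numbers for an effect only at larger amounts of compound), compound 1 gives 33 uM. Compound 2 `CCC1=C(O)c2c(oc(-c3cc(OC)c(OC)c(OC)c3)cc2=O)C(CC)(CC)C1=O` gives 46.7 uM in this assay, and compound 3 `CCC1=C(O)c2c(oc(-c3cc(Cl)c(OC)c(OC)c3)cc2=O)C(CC)(CC)C1=O` gives 21.8 uM. Among these three numbers compound 1 stands second highest; its distance to compound 2 and its distance to compound 3 both lie within the scatter, so no order between compound 1 and either neighbour can be read from them. For the measured compounds named here, the one step between measured compounds, a 2.1-fold lower number from compound 2 to compound 3 (0.33 log units; beyond the scatter), is modest and concerns only the substituents on the attached group.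

Compound 4 `CCC1=C(O)c2c(oc(-c3cccc(C)c3C)cc2=O)C(CC)(CC)C1=O` differs from compound 1 by 2,3-dimethylphenyl in place of 4-fluorophenyl on an aromatic carbon. Going by the values given here, no measured step matches this change. The step of a 2.1-fold lower number from compound 2 to compound 3 (0.33 log units; beyond the scatter) is the sole indication of how substituents on the attached group move the number in this assay, and it is small. Compound 4 is therefore expected to show no step beyond the scatter, with a 1.1-fold lower number from compound 1 to compound 4 (0.04 log units; within the scatter) as the estimated change from compound 1. The estimate for compound 4 in this assay is 30 uM, with a range from 10 uM to 90 uM.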

Compound 4, concentration for half-maximal effect: 3.1 uM
Beside the measured number, compound 4's estimate is 9.7-fold (0.99 log units) above it; the whole stated range lies above it.
By their numbers in this assay, from the lowest: compound 4; then compounds 3, 1 and 2 (each within the scatter of the next, the first and the last beyond it).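

For the compounds shown here, the change from 4-fluorophenyl to 2,3-dimethylphenyl, on the aromatic carbon next to the ring oxygen, gives in this assay an 11-fold lower number from compound 1 to compound 4 (1.03 log units; beyond the scatter) and is thus a large step, whereas the only earlier step, a 2.1-fold lower number from compound 2 to compound 3 (0.33 log units; beyond the scatter), was modest. The earlier compounds shown here therefore gave no sign that the choice of aryl group at this place could move the number so far. The counts for the two groups are close: the group entering has one more heavy atom and no fluorine, while both have one six-membered aromatic ring of carbon only, no hydrogen-bond donors or acceptors and no net charge, so the step arises without any change in those counts. Nothing given here bears on why the number moves this far.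

Going by these compounds, it remains open whether either methyl group alone accounts for the step, or whether both are needed in the 2,3-dimethylphenyl arrangement. It is also unknown how an amine, a carboxylic acid or a longer alkyl chain on the attached phenyl ring would read in this assay.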